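Taking the bromo group off compound 1

A few compounds are considered here, and "the series" means these few. Any claim that something is new, unique, unknown or untested is made for them only; others in the source may bear on it.

For the measured compounds named here, in a functional assay on MDA-MB-231 cells (Homo sapiens) for antiproliferative activity, read by MTT assay, with a stated time of 24 h (a lower number here means a stronger inhibitor, a higher number a weaker inhibitor), compound 1 (`COC(=O)c1scc(-c2ccc(NC(=O)c3ccc(C(F)(F)F)cc3Br)cc2)c1OC`) gives 19600 nM and holds the higher of the two numbers measured so far, which makes it the weaker inhibitor of the pair. Compound 2 (`COC(=O)c1scc(-c2ccc(NC(=O)c3cccc(OC(F)(F)F)c3)cc2)c1OC`) stands lower at 7540 nM and the gap between them lies beyond the usual scatter.

The next compound to be tested is compound 3 (`COC(=O)c1scc(-c2ccc(NC(=O)c3ccc(C(F)(F)F)cc3)cc2)c1OC`). It is compound 1 with hydrogen in place of bromo on an aromatic carbon and it keeps the trifluoromethyl group.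

Going by the values given here, no measured pair shows this change on its own, so any expectation here is rough. Compound 2 also carries no bromo and gives 7540 nM as its value, but it differs from compound 1 in other groups too, so it offers only a weak hint toward a lower number.

The expected change is a 1.8-fold lower number from compound 1 to compound 3 (0.25 log units; within the scatter) in the direction of a stronger inhibitor, a small step that may not clear the scatter. Compound 3 is estimated at 11000 nM in this assay with 4500 nM and 25000 nM as the expected ends of its range.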

Compound 3, half-maximal inhibitory concentration: 18300 nM
The estimate for compound 3 lay 1.7-fold (0.22 log units) below the measured number, and the stated range covers the measured number.
By their numbers in this assay, from the lowest: compound 2; then compounds 3 and 1 (each within the scatter of the next).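

Replacing the bromo group with hydrogen, at a position ortho to a large group and meta to a trifluoromethyl group, gives a 1.1-fold lower number from compound 1 to compound 3 (0.03 log units; within the scatter) in this assay. For the compounds shown here, this is the first comparison in which that single change stands alone, and it shows that, with the trifluoromethyl group kept and the rest of the molecule unchanged, the two compounds cannot be told apart in this measurement, so the bromo group makes no difference here beyond the scatter. No measurement shown explains why this position tolerates the change so quietly.

The compounds shown leave open whether this position is insensitive to any substituent or only to this swap, since a single pair cannot tell whether a different group there, such as an amine or a carboxylic acid, would move the number beyond the scatter. They also leave open whether removing the bromo group would have an equally small effect if the trifluoromethyl group were replaced by another group elsewhere on the same ring.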